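The compounds below may be only part of what the source reports. "The series", "measured", "known", "first", "only" and "open" are said of these compounds alone.

Two compounds of the series have numbers in an ADME assay on HT-29 cells (Homo sapiens) for inhibition, read by MTT assay, with a stated time of 72 h; a higher number here means a weaker inhibitor, a lower number a stronger inhibitor. Compound 1 `C=CC(=O)Nc1cccc(Nc2nc(N/N=C(\C)c3ccc(F)cc3F)ncc2Cl)c1` gives 4360 nM there. Compound 2 `COc1ccc(/C=N/Nc2ncc(Cl)c(Nc3cccc(NC(=O)/C=C/CN(C)C)c3)n2)cc1` gives 4820 nM in this assay, the higher of the two numbers, though the gap to compound 1 lies within the scatter. Compound 3 `C/C(=N\Nc1ncc(Cl)c(Nc2cccc(NC(=O)/C=C/CN(C)C)c2)n1)c1ccc(F)cc1F` differs from compound 2 by a group of 11 heavy atoms (8 carbon, 1 nitrogen, 2 fluorine; one six-membered aromatic ring of carbon only) in place of a group of 10 heavy atoms (8 carbon, 1 nitrogen, 1 oxygen; one six-membered aromatic ring of carbon only), on a nitrogen on an aromatic ring. Going by the values given here, the entering group is the one carried by compound 1, which in this assay gives 4360 nM and so sits close to compound 2. The step of a 1.1-fold lower number from compound 2 to compound 3 (0.03 log units; within the scatter) is therefore expected to stay within the scatter. Compound 3 is estimated at 4500 nM in this assay, with a range from 2000 nM to 10000 nM.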

Compound 3, half-maximal inhibitory concentration: 3460 nM
For compound 3 the middle estimate is 1.3-fold (0.11 log units) above the measured one; the measured number falls inside the stated range.
By their numbers in this assay, from the lowest: compounds 3, 1 and 2 (each within the scatter of the next).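

In this assay the exchange on the nitrogen on an aromatic ring stays within the scatter when the acrylamide side carries 3-(dimethylamino)prop-1-en-1-yl (a 1.4-fold lower number from compound 2 to compound 3 (0.14 log units; within the scatter)). Going by these compounds alone, the first direct pair at the carbonyl carbon, 3-(dimethylamino)prop-1-en-1-yl in place of vinyl, also stays within the scatter (a 1.3-fold lower number from compound 1 to compound 3 (0.10 log units; within the scatter)). Among these compounds, neither place yet gives a step beyond the scatter, and no evidence at hand bears on either step. Still open, from the compounds shown here alone, is whether a longer chain or a morpholine on the carbonyl carbon would give such a step. Going by these compounds, a carboxylic acid on the carbon-only aromatic ring is equally open.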